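The source may hold more compounds than are shown below. What is called first, only, known or untested is meant among the compounds shown, and "the series" means these compounds.

Compound 1 `C#CCNC1CCc2c(SCc3ccc(Cl)cc3)cccc21`: 180 nM
Compound 2 `C#CCNC1CCc2c(OCCc3cc(NC(=O)c4cccc(F)c4)ccc3Cl)cccc21`: > 20000 nM

In an assay on cells for inhibition of Amine oxidase [flavin-containing] B (Homo sapiens), read by fluorescence and Amplex Red, with stated times of 30 min and 15 min (on this read-out lower numbers stand for stronger inhibition and higher numbers for weaker inhibition), compound 1 gives 180 nM. For compound 2 the assay reports only a limit, > 20000 nM, the reading described by the limit of > 20000 nM in this assay, at which 1 of the 2 values shown sits. Compound 3 `C#CCNC1CCc2c(OCCc3cc(NC(=O)COC(C)=O)ccc3Cl)cccc21` differs from compound 2 by acetoxymethyl in place of 3-fluorophenyl on a carbonyl carbon. Within the data shown here, no step between two measured compounds covers such a change, so the expectation for compound 3 rests on the limit of compound 2 alone. The step that the limit leaves unreadable from compound 2 to compound 3 is expected to stay within the scatter. Compound 3 is estimated at 30000 nM, between 10000 nM and 100000 nM, most probably again only a limit.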

Compound 3, half-maximal inhibitory concentration: 480 nM
Compound 3: the middle estimate sits 63-fold (1.80 log units) above what was measured; measured number outside the range, below it.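

In this assay, swapping 3-fluorophenyl for acetoxymethyl on the carbonyl carbon gives an at least 41-fold lower number from compound 2 to compound 3 (1.61 log units; beyond the scatter). The group at this one place can therefore carry the read-out from the limit into a measurable range, and the rest of the structure of compound 2 does not by itself prevent inhibition. The reading of compound 2 is a limit, so the full size of the step stays unknown: the limit of > 20000 nM in this assay, at which 1 of the 3 values shown sits.

The compounds shown do not separate the loss of the aromatic ring from the arrival of the ester. Neither do they show how a plain methyl, a hydroxymethyl or an aminomethyl would read at this place.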